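The compounds below may be only part of what the source reports. "The series", "measured", "known", "first", "only" and "open" are said of these compounds alone.

Among the measured compounds shown here, compound 1, whose structure is `CN(C)CC(=O)Nc1cccc(Nc2ncc(F)c(Nc3ccc(F)cc3)n2)c1`, is the one member of this small set that gives an actual number: in a functional assay on KBVIN cells (Homo sapiens) for antiproliferative activity, read by sulforhodamine B assay, with a stated time of 3 days (on this read-out higher numbers stand for weaker inhibition of growth and lower numbers for stronger inhibition of growth), compound 1 gives 1810 nM. Compound 2, `O=C(Nc1cccc(Nc2ncc(F)c(Nc3ccc(F)cc3)n2)c1)c1ccccc1`, differs from it by a phenyl in place of (dimethylamino)methyl on a carbonyl carbon. For compound 2 this assay reports only a limit, > 10000 nM. Compound 3, `O=C(Nc1nccs1)c1cccc(Nc2ncc(F)c(Nc3ccc(F)cc3)n2)c1`, carries a (1,3-thiazol-2-yl)carbamoyl in place of (((dimethylamino)methyl)carbonyl)amino on an aromatic carbon. For compound 3 too this assay reports only a limit, > 10000 nM. The two measured steps are therefore read against the limit of > 10000 nM in this assay, at which 2 of the 3 values shown sit: an at least 5.5-fold higher number from compound 1 to compound 2 (0.74 log units; beyond the scatter), and an at least 5.5-fold higher number from compound 1 to compound 3 (0.74 log units; beyond the scatter). Between the two limits themselves, a step that the two limits leave unreadable from compound 2 to compound 3.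

The unmeasured compound 4, `COCC(=O)Nc1cccc(Nc2ncc(F)c(Nc3ccc(F)cc3)n2)c1`, keeps the whole amide arrangement of compound 1 and changes only its tip: methoxy in place of dimethylamino on a saturated chain carbon bound to a carbonyl carbon. This is a smaller alteration than either measured step, both of which removed the (dimethylamino)methyl group entirely and both of which weakened growth inhibition at least modestly. The expectation is that compound 4 weakens growth inhibition somewhat relative to compound 1, so that the estimated step is a 1.9-fold higher number from compound 1 to compound 4 (0.29 log units; within the scatter). Compound 4 is therefore estimated at 3500 nM, within a range from 1200 nM to 10000 nM.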

Compound 4, concentration for 50% growth inhibition: 3940 nM
Beside the measured number, compound 4's estimate is 1.1-fold (0.05 log units) below it; the measured number falls inside the stated range.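

In this assay, methoxy in place of dimethylamino on a saturated chain carbon bound to a carbonyl carbon gives a 2.2-fold higher number from compound 1 to compound 4 (0.34 log units; beyond the scatter), so this change costs only modest growth inhibition and, unlike the two earlier changes, leaves a measurable value. Dimethylamino is therefore not needed at this place for a measurable value, although compound 1, which carries it, keeps a modest advantage. Methoxymethyl in place of phenyl on the carbonyl carbon gives an at least 2.5-fold lower number from compound 2 to compound 4 (0.40 log units; beyond the scatter), and the ((methoxymethyl)carbonyl)amino group in place of (1,3-thiazol-2-yl)carbamoyl gives an at least 2.5-fold lower number from compound 3 to compound 4 (0.40 log units; beyond the scatter), both true sizes being possibly larger, as each is measured against a limit of the assay: the limit of > 10000 nM in this assay, at which 2 of the 4 values shown sit.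

The compounds shown leave open how other groups on this chain carbon, such as a hydroxyl, a primary amine or a morpholine ring, would compare with methoxy and dimethylamino. They also leave open whether a longer chain between the carbonyl and the end group would restore or further reduce growth inhibition.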